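Selenium-bearing core series: chain extension from compound 1

The source may report more compounds than this note shows. Statements on the series, on what has been measured and on what is new or still open speak of the compounds shown alone.

Measured compounds:
compound 1, `C[Se]c1nc(N)c2ccccc2n1`: 74800 nM
compound 2, `Sc1nc(NCc2ccccc2)c2ccccc2n1`: 63500 nM
compound 3, `C[Se]c1nc([Se]C)c2ccccc2n1`: 33800 nM

In a functional assay on HT-29 cells (Homo sapiens) for cytotoxicity, read by MTT assay, with a stated time of 72 h (a lower number here means a stronger inhibitor of growth, a higher number a weaker inhibitor of growth), compound 1 gives 74800 nM, the highest of the three numbers. Compound 2 stands within the scatter of compound 1, so the two cannot be told apart. Going by the values given here, compound 3 lies furthest from compound 1, with a 2.2-fold lower number from compound 1 to compound 3 (0.34 log units; beyond the scatter), the only step in the set that is beyond the scatter; it swaps one nitrogen atom for a methylseleno group and says nothing about the length of a chain on selenium.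

Compound 4, `CCCCC[Se]c1nc(N)c2ccccc2n1`, is compound 1 with butyl in place of hydrogen on a saturated chain carbon bound to a selenium atom. Among the compounds with values here, no measured pair changes a chain on selenium, and no measured pair changes anything on a saturated chain carbon at all, so the step from compound 1 to compound 4 has no direct precedent here. With nothing in the measured steps pointing either way, the expectation is a change that stays within the scatter, a 1.5-fold lower number from compound 1 to compound 4 (0.17 log units; within the scatter). The estimate for compound 4 in this assay is therefore 50000 nM, with a range from 15000 nM to 160000 nM that allows for a weak effect of the added butyl in either direction.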

Compound 4, concentration for total growth inhibition: > 100000 nM
Compound 4: only a limit was reported; the forecaster's own chance of this, stated with the estimate: 15%; middle value at least 2.0-fold (0.30 log units) away from the limit.
By their numbers in this assay, from the lowest: compounds 3, 2 and 1 (each within the scatter of the next, the first and the last beyond it). At a limit, above all of these: compound 4.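

In this assay compound 4 is reported only as a limit, > 100000 nM. Going by these compounds alone, this is the only reading on the saturated chain carbon bound to a selenium atom, and the change from methyl to pentyl gives an at least 1.3-fold higher number from compound 1 to compound 4 (0.12 log units; that floor lies within the scatter), so the longer chain shows no gain in growth inhibition over compound 1, although the floor of that step does not separate the two compounds and the true size of the step remains unknown. Any reading of this position therefore rests on a single censored value, and the series gives no measured trend with chain length: the limit of > 100000 nM in this assay, at which 1 of the 4 values shown sits.

The compounds shown leave open how an ethyl or propyl chain on selenium would read in this assay, and whether a pentyl chain ending in an amine or a carboxylic acid would return a number rather than a limit. They also leave open whether the change from methyl to pentyl would carry over to the methylseleno groups of compound 3.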